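Replacing methylamino on the shared core of compound 2

A few compounds are considered here, and "the series" means these few. Any claim that something is new, unique, unknown or untested is made for them only; others in the source may bear on it.

Measured in a functional assay on HCT-116 cells (Homo sapiens) for cytotoxicity, read by MTT assay, with a stated time of 72 h; on this read-out higher numbers stand for weaker inhibition and lower numbers for stronger inhibition:
compound 1 `Nc1cccc(Nc2c(C(=O)NCc3ccc(F)cc3)nc(Br)c3cccnc23)c1`: > 10000 nM
compound 2 `CNc1c(C(=O)NCc2ccc(F)cc2)nc(Br)c2cccnc12`: > 20000 nM

In this assay compound 1 reports only a limit, > 10000 nM. Compound 2 likewise stands at a limit, > 20000 nM, and no number is known for either compound.

The next compound is compound 3 `Cc1ccc(S(=O)(=O)Oc2c(C(=O)NCc3ccc(F)cc3)nc(Br)c3cccnc23)cc1`. It carries ((4-methylphenyl)sulfonyl)oxy in place of methylamino on an aromatic carbon, para to a bromo group (((4-methylphenyl)sulfonyl)oxy in place of methylamino on an aromatic carbon).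

Among the compounds with values here, one measured step bears on this position: a step that the two limits leave unreadable from compound 1 to compound 2. It gives no size to carry over, and it shows no direction. Both measured compounds keep a nitrogen on this aromatic carbon, whereas compound 3 does not, so the change goes beyond what they cover. No clear step is therefore expected in this assay, although a modest move towards stronger inhibition cannot be excluded, and the reading may again be only a limit.

The estimated step is an at least 1.6-fold lower number from compound 2 to compound 3 (0.22 log units; that floor lies within the scatter). Compound 3 is expected at 12000 nM, with an estimated range from 3000 nM to 40000 nM.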

Compound 3, half-maximal inhibitory concentration: > 20000 nM
Compound 3 ended at the assay's limit (the forecaster's own chance of this, stated with the estimate: 55%); middle value at least 1.6-fold (0.22 log units) away from the limit.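

In this assay compound 3 reports only a limit, > 20000 nM. Within the data shown here, compound 1 and compound 2 also stand at limits, so no step among the three can be read. The compounds shown leave open what actual value any of them has, and whether any group on this aromatic carbon gives a measurable inhibition.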